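The source may hold more compounds than are shown below. What is called first, only, known or untested is meant among the compounds shown, and "the series" means these compounds.

Of the compounds shown here, two built on a shared core have been tested in a functional assay on MCF7 cells (Homo sapiens) for antiproliferative activity, read by MTT assay; a higher number here means a weaker inhibitor, a lower number a stronger inhibitor. Compound 1, with the structure `CC(C)Nc1nc(Nc2ccc(N3CCN(C)CC3)cc2)ncc1/N=C/c1cccs1`, gives 91100 nM in this assay. Compound 2, with the structure `CCOC(=O)/C=N/c1cnc(Nc2ccc(S(N)(=O)=O)cc2)nc1NC(C)C`, gives 58800 nM in this assay. Of these two numbers compound 2 holds the lower one, and compound 1 stands a short distance away, a gap that lies within the scatter of repeated measurements, so no order can be drawn from it.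

Compound 3, with the structure `CC(C)Nc1nc(Nc2ccc(S(N)(=O)=O)cc2)ncc1/N=C/c1cccs1`, has not yet been measured. It differs from compound 2 in one place: thiophen-2-yl in place of ethoxycarbonyl on a carbon with a double bond to nitrogen. Going by the values given here, no pair of measured compounds differs only in this way, so the size of this step cannot be read from the data. Compound 3 carries on the carbon with a double bond to nitrogen the same group that compound 1 carries there, and compound 1 gives 91100 nM in this assay. Since both measured numbers lie close together, no step beyond the scatter is expected. On that basis compound 3 is expected to give 70000 nM in this assay, with a range from 25000 nM to 200000 nM. The expected step from compound 2 to compound 3 is thus a 1.2-fold higher number from compound 2 to compound 3 (0.08 log units; within the scatter), within the scatter.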

Compound 3, half-maximal inhibitory concentration: 50200 nM
The estimate for compound 3 lay 1.4-fold (0.14 log units) above the measured number; the measured number falls inside the stated range.
By their numbers in this assay, from the lowest: compounds 3, 2 and 1 (each within the scatter of the next).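

In this assay, the change at the carbon with a double bond to nitrogen now has a size: thiophen-2-yl in place of ethoxycarbonyl gives a 1.2-fold lower number from compound 2 to compound 3 (0.07 log units; within the scatter), so at this place the data do not separate an open ester group from a five-membered aromatic ring of the same heavy-atom count. Going by these compounds alone, the same compound also gives a first reading at a second place, as sulfamoyl in place of 4-methylpiperazin-1-yl on an aromatic carbon gives a 1.8-fold lower number from compound 1 to compound 3 (0.26 log units; within the scatter), and this step likewise cannot be told from repeated-measurement noise. Nothing available offers an explanation for either reading.

The compounds shown leave open whether an amine, a carboxylic acid or a longer chain on the carbon with a double bond to nitrogen would give a step beyond the scatter. From the compounds shown here alone, each of the two changes has also been read only once, so it remains open whether the step from ethoxycarbonyl to thiophen-2-yl would be the same with 4-methylpiperazin-1-yl on the aromatic carbon.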